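The source may hold more compounds than are shown below. What is called first, only, known or untested is meant among the compounds shown, and "the series" means these compounds.

Compound 1 `CCCN(CCC)c1nc(N2CCN(C(=O)c3ccco3)[C@@H]3CCCC[C@@H]32)nc2cc(OC)c(OC)cc12`: 58.9 nM
Compound 2 `CCCCCC(=O)N1CCN(c2nc(N)c3cc(OC)c(OC)cc3n2)[C@@H]2CCCC[C@@H]21`: 155 nM
Compound 3 `COc1cc2nc(N3CCN(C(=O)C(C)(C)C)[C@H]4CCCC[C@H]43)nc(N)c2cc1OC`: 141 nM

These three were measured in a functional assay (strain Wistar) for antagonist activity at Alpha-1D adrenergic receptor (Rattus norvegicus), with a stated time of 30 min, in the presence of a further agent that is not named here; a higher number here means weaker binding, a lower number tighter binding. Compound 3 stands second highest of the three numbers, nearest compound 2 with a gap within the scatter, and furthest from compound 1, whose lower number lies beyond the scatter. Compound 4 `COc1cc2nc(N3CCN(C(=O)OCc4ccccc4)[C@H]4CCCC[C@H]43)nc(N)c2cc1OC` differs from compound 3 by benzyloxy in place of tert-butyl on a carbonyl carbon. Going by the values given here, the only measured step touching the same carbonyl carbon is a 1.1-fold lower number from compound 2 to compound 3 (0.04 log units; within the scatter), within the scatter, which suggests that groups on this carbonyl carbon change the number little. Compound 4 is therefore expected to show no step beyond the scatter, a 1.0-fold lower number from compound 3 to compound 4 (0.00 log units; within the scatter). The estimate for compound 4 is 140 nM, with a range from 50 nM to 400 nM.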

Compound 4, dissociation constant: 240 nM
Compound 4: the middle estimate sits 1.7-fold (0.23 log units) below what was measured, and the stated range covers the measured number.
By their numbers in this assay, from the lowest: compound 1; then compounds 3, 2 and 4 (each within the scatter of the next).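

Benzyloxy brings an aromatic ring and an oxygen to this carbonyl carbon, yet in this assay the step stays within the scatter (a 1.7-fold higher number from compound 3 to compound 4 (0.23 log units; within the scatter)), and the same holds against the pentyl amide (a 1.5-fold higher number from compound 2 to compound 4 (0.19 log units; within the scatter)). Pentyl, tert-butyl and benzyloxy therefore give no step beyond the scatter among compound 2, compound 3 and compound 4, so this position now tolerates an aromatic group as well as open and branched chains. Nothing available explains this tolerance. On these data alone, whether a group carrying an amine or a carboxylic acid would fit this pattern remains open. So does whether benzyloxy would behave the same way on the core of compound 1.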